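Two Fatty Esters of a Cytosine Nucleoside, Z and E

The compounds below may be only part of what the source reports. "The series", "measured", "known", "first", "only" and "open" are said of these compounds alone.

Compound 1 `CCCCCCCC/C=C\CCCCCCCCCCCC(=O)O[C@H]1[C@H](O)[C@H](n2ccc(N)nc2=O)O[C@@H]1CO` carries one long unsaturated chain on its sugar, and in a functional assay on HeLa cells (Homo sapiens) for cytotoxicity, read by cell counting, with a stated time of 48 h (on this read-out higher numbers stand for an effect only at larger amounts of compound and lower numbers for an effect already at smaller amounts), compound 1 gives 0.16 ug/mL. Compound 2 `CCCCCCCC/C=C\CCCCCCCC(=O)OC[C@H]1O[C@@H](n2ccc(N)nc2=O)[C@@H](O)[C@@H]1OC(=O)CCCCCCC/C=C\CCCCCCCC` carries two such chains, and in this assay compound 2 gives 1.1 ug/mL, the higher of the two numbers measured here. Compound 3 `CCCCCCCC/C=C/CCCCCCCC(=O)OC[C@H]1O[C@@H](n2ccc(N)nc2=O)[C@@H](O)[C@@H]1OC(=O)CCCCCCC/C=C/CCCCCCCC` is built from compound 2 with this change: the two compounds have the same atoms and bonds and differ only in configuration as drawn: 2 of 6 stereo elements differ; a double bond is drawn Z in compound 2 and E in compound 3; a double bond is drawn Z in compound 2 and E in compound 3. Among the measured compounds shown here, no measured pair shows what such a change does, so the step of a 1.2-fold higher number from compound 2 to compound 3 (0.07 log units; within the scatter) is expected to stay within the usual scatter, in no fixed direction. Compound 3 is therefore estimated at 1.3 ug/mL, from 0.5 ug/mL to 3.5 ug/mL.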

Compound 3, concentration for half-maximal effect: 2.5 ug/mL
The estimate for compound 3 lay 1.9-fold (0.28 log units) below the measured number; the measured number falls inside the stated range.
By their numbers in this assay, from the lowest: compound 1; then compound 2; then compound 3.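

Turning the double bonds of both chains from Z to E gives a 2.3-fold higher number from compound 2 to compound 3 (0.36 log units; beyond the scatter) in this assay, so double-bond geometry alone can move the number beyond the usual scatter. Among the compounds shown here, until now, no measured pair had isolated this change. The step can be put down to that geometry, because nothing else separates the pair: the fact that compounds 2 and 3 differ only in the configuration as drawn

Whether one double bond or both together account for the step stays open. So does the result of placing a saturated chain, such as stearoyl, at the same places on the sugar.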